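This account rests on a few compounds, and the source may have more. Where it says the series, first, only, none or still open, it means among the compounds named here.

In an ADME assay on Vero 76 cells (Chlorocebus sabaeus) for cytotoxicity, read by crystal violet staining, with a stated time of 96 h (a higher number here means that more compound is tolerated, a lower number that less compound is tolerated), compound 1 `CC[C@H]1CC[C@H](c2ccc(NC(=S)Nc3cccc(C(F)(F)F)c3)cc2)CC1` gives 10000 nM, and compound 2 `FC(F)(F)c1cccc(NC(=S)Nc2ccc(Cl)cc2)c1` gives 11000 nM. For the measured compounds named here, these are the only two numbers so far, and they sit within the scatter of each other, so compound 2 stands level with compound 1. The next compound, compound 3 `O=[N+]([O-])c1ccc(NC(=S)Nc2cccc(C(F)(F)F)c2)cc1`, keeps the rest of compound 2 and alters a single group: nitro in place of chloro on an aromatic carbon. Put simply, nitro takes the place of chloro on an aromatic carbon, para to a large group. Going by the values given here, no measured compound carries nitro, so the data cannot show directly what this group does here. Among the compounds with values here, the one measured step that bears on the change, a 1.1-fold higher number from compound 1 to compound 2 (0.04 log units; within the scatter), also swapped one group for another on an aromatic carbon and stayed within the scatter. On that thin evidence, no step beyond the scatter is expected in this assay. The expected step is a 1.1-fold lower number from compound 2 to compound 3 (0.04 log units; within the scatter), which is an estimate and not a measurement. For compound 3 the estimated value is 10000 nM, with an expected range from 4000 nM to 25000 nM.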

Compound 3, half-maximal cytotoxic concentration: 10000 nM
For compound 3 middle estimate and measured number coincide at the digits printed, within the range that was stated.
By their numbers in this assay, from the lowest: compounds 1, 3 and 2 (each within the scatter of the next).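

In this assay, this aromatic carbon, para to a large group, now has a third occupant, and it differs from chloro in its count of atoms: nitro has three heavy atoms and two hydrogen-bond acceptors, while chloro has one heavy atom and no acceptors. Even so, the swap gives a 1.1-fold lower number from compound 2 to compound 3 (0.04 log units; within the scatter), and setting nitro against 4-ethylcyclohexyl gives no change at the digits printed from compound 1 to compound 3 (within the scatter), so chloro, nitro and 4-ethylcyclohexyl all stand level at this place, and across these three compounds the choice of group has not moved the tolerated concentration beyond the scatter. No measurement at hand offers a reason for this levelness.

For the compounds shown here, still open is whether an amine, a carboxylic acid or a longer chain on this same aromatic carbon would also stand level with these three groups, or would be the first to produce a step beyond the scatter. Also open, as far as these compounds go, is what happens to the tolerated concentration when the trifluoromethyl group, which all three compounds share, is replaced by another group such as a methoxy or a hydrogen.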